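The source may hold more compounds than are shown below. What is called first, only, known or untested is meant among the compounds shown, and "the series" means these compounds.

Of the compounds shown here, three have been measured in a functional assay on HEK293 cells with D(4) dopamine receptor (Homo sapiens) as the target, read by FLIPR; on this read-out lower numbers stand for smaller maximal responses and higher numbers for larger maximal responses. Compound 1 `N#Cc1cccnc1N1CCN(CC/C(=N\O)c2ccccc2)CC1` gives 64% in this assay, the highest of the three numbers. Compound 2 `N#Cc1cccnc1N1CCN(CC/C(=N/O)c2ccccc2)CC1`, which has the same atoms and bonds as compound 1 and differs only in configuration as drawn, with one double bond drawn E in compound 1 and Z in compound 2, gives 49%. Compound 3 `O/N=C(\CCN1CCN(c2ncccn2)CC1)c1ccccc1`, which carries pyrimidin-2-yl in place of 3-cyanopyridin-2-yl on an amine nitrogen in a ring, gives 49%. The step of a number 15 percentage points lower from compound 1 to compound 2 (beyond the scatter) and the step of a number 15 percentage points lower from compound 1 to compound 3 (beyond the scatter) are each beyond the scatter yet modest.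

Compound 4 `CCO/N=C(\CCN1CCN(c2ncccc2C#N)CC1)c1ccccc1` differs from compound 1 by ethyl in place of hydrogen on an oxygen. Neither measured step touches the oxygen: one concerns the drawn configuration, the other the group on an amine nitrogen in a ring. Among the compounds with values here, both move away from compound 1 by a modest drop, and no step shows a rise. The step of a number 9 percentage points lower from compound 1 to compound 4 (within the scatter) is therefore expected to be small, with a modest drop as the likelier direction. Compound 4 is estimated at 55%, with a range from 35% to 75%.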

Compound 4, largest response reached (reported as efficacy), in percent of the reference or control that the assay uses: 64%
For compound 4 the middle estimate is 9 percentage points below the measured one; the measured number falls inside the stated range.
By their numbers in this assay, from the lowest: compounds 2 and 3 (each within the scatter of the next); then compounds 1 and 4 (each within the scatter of the next).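

Ethyl in place of hydrogen on this oxygen, which turns hydroxy into ethoxy, gives no change at the digits printed from compound 1 to compound 4 (within the scatter) in this assay. The earlier steps shown here changed the drawn configuration and the group on the ring nitrogen, and each lowered the number beyond the scatter, whereas this first change at the oxygen does not; for this pair, then, the hydrogen on the oxygen is not needed to keep the maximal response. Nothing at hand explains why the number holds when this group changes.

On these data alone, whether a methyl, a benzyl or a longer chain carrying an amine or a carboxylic acid would be tolerated on this oxygen remains open. As far as these compounds go, it is also open whether ethyl would have the same effect on compound 2 or compound 3.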